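The source may hold more compounds than are shown below. What is called first, only, known or untested is meant among the compounds shown, and "the series" means these compounds.

Compound 1 `O=C(O)COC/C=C1\CC2C[C@@H](O)[C@H](/C=C/[C@@H](O)C3Cc4ccccc4C3)C2C1` and compound 2 `CC1([C@H](O)/C=C/[C@@H]2C3C/C(=C/COCC(=O)O)CC3C[C@H]2O)Cc2ccccc2C1` share one core, while compound 3 `O=C(O)COCCC1=C[C@H]2C[C@@H](O)[C@H](/C=C/[C@@H](O)C3Cc4ccccc4C3)C2C1` and compound 4 `CC1([C@H](O)/C=C/[C@@H]2C3CC(CCOCC(=O)O)=C[C@H]3C[C@H]2O)Cc2ccccc2C1` share another; the difference between the two cores is not broken down here. In a functional assay on the whole organism (stomach) for inhibition, with Rattus norvegicus as the target (a higher number here means that more compound is needed for the effect, a lower number that less compound is needed), compound 1 gives 0.0675 mg/kg, and compound 2 gives 0.0397 mg/kg. The change from compound 1 to compound 2 is methyl in place of hydrogen on a saturated ring carbon, and it made a 1.7-fold lower number from compound 1 to compound 2 (0.23 log units; within the scatter). In this assay compound 3 gives 0.0274 mg/kg. Compound 4 carries the same change on the core of compound 3, namely (methyl in place of hydrogen on a saturated ring carbon). Because compound 1 to compound 2 gave a 1.7-fold lower number from compound 1 to compound 2 (0.23 log units; within the scatter), the step from compound 3 to compound 4 is expected to be similar, a 1.4-fold lower number from compound 3 to compound 4 (0.16 log units; within the scatter). Compound 4 is therefore estimated at 0.019 mg/kg, between 0.008 mg/kg and 0.045 mg/kg.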

Compound 4, dose for half-maximal effect: 0.006 mg/kg
Compound 4: the middle estimate sits 3.2-fold (0.50 log units) above what was measured; measured number below the stated range.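

In this assay, methyl in place of hydrogen on a saturated ring carbon made a 4.6-fold lower number from compound 3 to compound 4 (0.66 log units; beyond the scatter). The size of the step did not carry over from one core to the other, and the earlier step, being within the scatter, cannot establish a shared direction: the same change on two cores in this assay, a 1.7-fold lower number (0.23 log units; within the scatter) from compound 1 to compound 2 and a 4.6-fold lower number (0.66 log units; beyond the scatter) from compound 3 to compound 4, 2.7-fold (0.43 log units) apart, beyond the scatter of two such steps. This shows that, for these two pairs, the step measured on one core did not fix its size on the other, but it does not show which difference between the cores matters or that other cores in the series would behave alike.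

The compounds shown leave open how an ethyl group or a fluorine atom at the same saturated ring carbon would read in this assay on either core.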